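A few compounds are considered here, and "the series" means these few. Any claim that something is new, unique, unknown or untested is made for them only; others in the source may bear on it.

In a physicochemical assay for solubility, measured as kinetic solubility (on this read-out lower numbers stand for lower solubility and higher numbers for higher solubility), compound 1 `Cc1cc(C)c(CN2CCc3c(Cl)cc([C@H](CO)[C@H]4CCOC4)c(Cl)c3C2=O)c(=O)[nH]1` gives 570000 nM, compound 2 `Cc1cc(C)c(CN2CCc3c(Cl)cc([C@H](CO)[C@@H]4CCCO4)c(Cl)c3C2=O)c(=O)[nH]1` gives 400000 nM and compound 3 `Cc1cc(C)c(CN2CCc3c(Cl)cc([C@@H](CO)[C@@H]4CCCO4)c(Cl)c3C2=O)c(=O)[nH]1` gives 550000 nM. Compound 3 therefore lies within the scatter of both other compounds, and the three form a single level. The change from compound 3 to compound 4 `Cc1cc(C)c(CN2CCc3c(Cl)cc(-c4c(C)noc4C)c(Cl)c3C2=O)c(=O)[nH]1` is a group of 7 heavy atoms (5 carbon, 1 nitrogen, 1 oxygen; one five-membered aromatic ring with 2 hetero atoms) in place of a group of 8 heavy atoms (6 carbon, 2 oxygen; one five-membered non-aromatic ring with 1 hetero atom), on an aromatic carbon. The measured steps bear on this change only indirectly. a 1.4-fold lower number from compound 1 to compound 2 (0.15 log units; within the scatter), a 1.0-fold lower number from compound 1 to compound 3 (0.02 log units; within the scatter) and a 1.4-fold higher number from compound 2 to compound 3 (0.14 log units; within the scatter) all stay within the scatter, but every compound in them keeps a five-membered non-aromatic ring with 1 hetero atom. None of them shows that ring giving way to a five-membered aromatic ring with 2 hetero atoms, so they set no size for this exchange. In this assay, for the measured compounds named here, a lower number beyond the scatter is nevertheless expected, with a wide range, since the only anchor is compound 3 at 550000 nM. The expected change is a 9.2-fold lower number from compound 3 to compound 4 (0.96 log units; beyond the scatter). Compound 4 is estimated at 60000 nM, with an expected range of 10000 nM to 300000 nM.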

Compound 4, solubility: 93000 nM
The estimate for compound 4 lay 1.6-fold (0.19 log units) below the measured number; low and high end bracket the measured number.
By their numbers in this assay, from the lowest: compound 4; then compounds 2, 3 and 1 (each within the scatter of the next).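

For the compounds shown here, at this aromatic carbon, ortho to a chloro group, 3,5-dimethyl-1,2-oxazol-4-yl in place of the group with the five-membered non-aromatic ring moves this assay beyond the scatter, which no earlier step did: a 5.9-fold lower number from compound 3 to compound 4 (0.77 log units; beyond the scatter), a 4.3-fold lower number from compound 2 to compound 4 (0.63 log units; beyond the scatter) and a 6.1-fold lower number from compound 1 to compound 4 (0.79 log units; beyond the scatter). All three steps run the same way, so the result does not hang on one starting compound or on where the non-aromatic ring is attached. Two of the starting compounds stand within the scatter of each other and give steps in the same direction, and they form a stereo pair: the fact that compounds 2 and 3 differ only in the configuration as drawn.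

The compounds shown do not separate the aromatic ring itself from its two methyl groups. From the compounds shown here alone, whether a phenyl ring, a pyrazole or an open chain ending in a hydroxyl group at this carbon would give a step of like size stays open.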